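Swapping propyl for tert-butyl: an expected shift in potency

The source may hold more compounds than are shown below. What is called first, only, known or untested is meant among the compounds shown, and "the series" means these compounds.

Two measured compounds share one core and differ only in the group on a carbon with a double bond to nitrogen. In a functional assay on cells (Burkitts lymphoma cell, Homo sapiens) for antiproliferative activity, read by MTT assay (on this read-out higher numbers stand for weaker inhibition and lower numbers for stronger inhibition), compound 1 `CC(C)/C(=N\Nc1nc2ccccc2o1)c1ccccn1` gives 14 nM, while compound 2 `CCC/C(=N\Nc1nc2ccccc2o1)c1ccccn1` gives 6 nM. For the measured compounds named here, the single measured step is a 2.3-fold lower number from compound 1 to compound 2 (0.37 log units; beyond the scatter), so compound 2 holds the lower of the two numbers, with compound 1 as its only neighbour. Compound 3 `CC(C)(C)/C(=N\Nc1nc2ccccc2o1)c1ccccn1` has not yet been measured; its change from compound 2 is tert-butyl in place of propyl on a carbon with a double bond to nitrogen. Going by the values given here, only that one step bears on it: there the branched isopropyl stood at the higher number and the straight propyl chain at the lower, and tert-butyl is a still more branched group. In this assay the expected step is therefore a 3.3-fold higher number from compound 2 to compound 3 (0.52 log units; beyond the scatter), toward a higher number. For compound 3 a value of about 20 nM is estimated, with a range from 5 nM to 80 nM.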

Compound 3, half-maximal inhibitory concentration: > 10000 nM
Compound 3 gave a limit, no number; the forecaster's own chance of this, stated with the estimate: 3%; middle value at least 500-fold (2.69 log units) from the limit.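

Compound 3 gave only a limit in this assay, not a number: the limit of > 10000 nM in this assay, at which 1 of the 3 values shown sits.

Even so, the change at this carbon with a double bond to nitrogen is far from gradual. The earlier move between branched isopropyl and straight propyl was only modest, whereas the new data show an at least 1600-fold higher number from compound 2 to compound 3 (3.22 log units; beyond the scatter), and adding one methyl to the isopropyl group gives an at least 710-fold higher number from compound 1 to compound 3 (2.85 log units; beyond the scatter), so activity in this series can collapse with a single extra carbon.

How far the true value of compound 3 lies past the limit remains unknown, and these compounds give no reason for the loss. Also open, going by these compounds, is whether a longer chain such as butyl, or a cyclopropyl ring, at the same place would keep the low number of compound 2 or lose it as tert-butyl does.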